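Chain shortening on the dihydroxy flavone series

The source may report more compounds than this note shows. Statements on the series, on what has been measured and on what is new or still open speak of the compounds shown alone.

Compound 1 `CN(C)CCCCOc1c(O)cc(O)c2c(=O)cc(-c3ccccc3)oc12` is read in a functional assay on A549 cells (Homo sapiens) for cytotoxicity, read by MTT assay, with a stated time of 48 h; a higher number here means a weaker inhibitor, a lower number a stronger inhibitor. In this assay compound 1 gives only a limit, > 100000 nM, and so stands without a number of its own (the limit of > 100000 nM in this assay, at which 1 of the 2 values shown sits). Going by the values given here, compound 2 `COc1c(OCCCN2CCCC2)cc(O)c2c(=O)cc(-c3ccccc3)oc12` gives 1390 nM in this assay; no step to compound 1 is taken. Compound 3 `CN(C)CCCOc1c(O)cc(O)c2c(=O)cc(-c3ccccc3)oc12` differs from compound 1 by dimethylamino in place of (dimethylamino)methyl on a saturated chain carbon, three bonds along the chain from an oxygen on an aromatic ring. Among the compounds with values here, no measured step of this kind is available, so the expected step of an at least 1.2-fold lower number from compound 1 to compound 3 (0.09 log units; that floor lies within the scatter) is small, none beyond the scatter, in either direction. Compound 3 is estimated at 80000 nM in this assay, within 15000 nM to 300000 nM, and may again come back only as a limit.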

Compound 3, half-maximal inhibitory concentration: > 100000 nM
Compound 3: no number, only a limit (the forecaster's own chance of this, stated with the estimate: 55%); at least 1.2-fold (0.09 log units) between middle value and limit.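

Compound 1 and compound 3 both come back only as limits in this assay, so no step can be read between them: the limit of > 100000 nM in this assay, at which 2 of the 3 values shown sit.

As far as these compounds go, whether 3-(dimethylamino)propyl and 4-(dimethylamino)butyl differ at all on the shared core in this assay stays open.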